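The source may report more compounds than this note shows. Statements on the series, on what has been measured and on what is new or still open speak of the compounds shown alone.

In an ADME assay on HepG2 cells (Homo sapiens) for cytotoxicity, with a stated time of 72 h (on this read-out higher numbers stand for an effect only at larger amounts of compound and lower numbers for an effect already at smaller amounts), compound 1 `Cc1cc(NC(=O)Nc2cccc([N+](=O)[O-])c2)c2ccccc2n1` gives > 25000 nM, which is a limit and not a number. Compound 2 `CSc1ccccc1NC(=O)Nc1cc(C)nc2ccccc12` also gives a limit, > 25000 nM. Compound 3 `Cc1cc(NC(=O)Nc2ccccc2C(N)=O)c2ccccc2n1` gives a limit too, > 25000 nM. Among the measured compounds shown here, the one measured step is a step that the two limits leave unreadable from compound 2 to compound 3, so it offers no size to carry over. For the measured compounds named here, the series so far shows (the limit of > 25000 nM in this assay, at which 3 of the 3 values shown sit). Compound 4 `COC(=O)c1cccc(NC(=O)Nc2cc(C)nc3ccccc23)c1` differs from compound 1 by methoxycarbonyl in place of nitro on an aromatic carbon, with methoxycarbonyl in place of nitro on an aromatic carbon. Going by the values given here, with the limit of > 25000 nM in this assay, at which 3 of the 3 values shown sit, as the only guide, no step beyond the scatter is expected in this assay. The expected change is a step that the limit leaves unreadable from compound 1 to compound 4. For compound 4 the estimated value is 30000 nM, with an expected range from 15000 nM to 60000 nM.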

Compound 4, half-maximal effective concentration: 23000 nM
Compound 4: the middle estimate sits 1.3-fold (0.12 log units) above what was measured, within the range that was stated.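

In this assay, among the compounds shown here, compound 4, with methoxycarbonyl in place of nitro on an aromatic carbon meta to a large group, gives 23000 nM, the first number rather than a limit. The change reads as an at least 1.0-fold lower number from compound 1 to compound 4 (0.03 log units; that floor lies within the scatter), and this is only a floor, so the true size of the step cannot be read. Most of the series still rests on one limit: the limit of > 25000 nM in this assay, at which 3 of the 4 values shown sit.

Going by these compounds, whether any change at this position can move the value beyond the scatter remains open. An amine or a carboxylic acid in place of methoxycarbonyl would test that.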